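Moving the Methyl Around the Anilino Ring

The compounds below may be only part of what the source reports. "The series", "measured", "known", "first", "only" and "open" are said of these compounds alone.

Within the data shown here, compound 2 `Cc1ccccc1Nc1ccc(C#N)cc1S(=O)(=O)NC(=O)NC(C)(C)C` gives 4780 nM in a functional assay on HEK293 cells for antagonist activity at thromboxane A2 receptor (Homo sapiens), read by fluorescence and calcium flux (on this read-out higher numbers stand for weaker inhibition and lower numbers for stronger inhibition), and stands highest of the two numbers so far; its nearest neighbour, compound 1 `Cc1ccccc1Oc1ccc(C#N)cc1S(=O)(=O)NC(=O)NC(C)(C)C`, gives 1470 nM. Among the measured compounds shown here, the only measured step, a 3.3-fold higher number from compound 1 to compound 2 (0.51 log units; beyond the scatter), alters a different part of the molecule and so does not bear directly on the present change. Compound 3 `Cc1ccc(Nc2ccc(C#N)cc2S(=O)(=O)NC(=O)NC(C)(C)C)cc1` differs from compound 2 by 4-methylphenyl in place of 2-methylphenyl on a nitrogen on an aromatic ring. For the measured compounds named here, with no step informing it, no movement beyond the scatter is expected, a 1.2-fold lower number from compound 2 to compound 3 (0.08 log units; within the scatter). Compound 3 is therefore estimated at 4000 nM, within a range from 1300 nM to 12000 nM.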

Compound 3, half-maximal inhibitory concentration: 1040 nM
Compound 3: middle estimate off by 3.8-fold (0.59 log units), on the high side; measured number below the stated range.
By their numbers in this assay, from the lowest: compounds 3 and 1 (each within the scatter of the next); then compound 2.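

On a nitrogen on an aromatic ring, where the methyl sits matters in this assay: 4-methylphenyl in place of 2-methylphenyl, with the same atoms joined differently, gives a 4.6-fold lower number from compound 2 to compound 3 (0.66 log units; beyond the scatter). The step of a 1.4-fold lower number from compound 1 to compound 3 (0.15 log units; within the scatter) lies within the scatter, so the higher number of compound 2 does not extend to every compound carrying the amino link. Nothing measured here accounts for this shift.

As far as these compounds go, it remains open whether a chlorine atom or a methoxy group in place of the methyl would behave the same way. From the compounds shown here alone, it is also open whether moving the methyl has a similar effect in the 2-methylphenoxy series.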